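A few compounds are considered here, and "the series" means these few. Any claim that something is new, unique, unknown or untested is made for them only; others in the source may bear on it.

Compound 1 `Cc1cccc(NC(=O)Nc2cccc(CNc3nccnc3Cl)c2)c1` gives 14600 nM.
Compound 2 `CS(=O)(=O)c1ccc(NC(=O)Nc2cccc(CNc3nccnc3Cl)c2)cc1` gives 12300 nM.

In a functional assay on MGC-803 cells (Homo sapiens) for antiproliferative activity, read by MTT assay, with a stated time of 48 h (on this read-out higher numbers stand for weaker inhibition and lower numbers for stronger inhibition), compound 1 gives 14600 nM, the highest of the two numbers shown. Compound 2 gives 12300 nM in this assay, and the two values lie within the scatter of each other, so neither compound can be set above the other on these data. Compound 3 `O=C(Nc1cccc(CNc2nccnc2Cl)c1)Nc1ccccc1Cl` has not yet been measured in this assay. It shares the core of compound 1 and differs from it in one place: 2-chlorophenyl in place of 3-methylphenyl on an amide-type nitrogen. For the measured compounds named here, no step between two measured compounds with a single difference exists here, so the size of this change in this assay has no precedent among the measured pairs. Given that both measured compounds sit close together, and that the change swaps one 7-heavy-atom ring for another, no movement beyond the scatter is expected. Compound 3 is therefore expected to give about 13000 nM, with a likely range from 5000 nM to 35000 nM. The expected step of a 1.1-fold lower number from compound 1 to compound 3 (0.05 log units; within the scatter) amounts to no change beyond the scatter.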

Compound 3, half-maximal inhibitory concentration: 7130 nM
Compound 3: middle estimate off by 1.8-fold (0.26 log units), on the high side; the range from low to high includes it.
By their numbers in this assay, from the lowest: compounds 3, 2 and 1 (each within the scatter of the next, the first and the last beyond it).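

In this assay, 2-chlorophenyl in place of 3-methylphenyl on the amide-type nitrogen gives a 2.0-fold lower number from compound 1 to compound 3 (0.31 log units; beyond the scatter), a modest step but the first single-place difference in this series that can be read at all. It shows that the number responds to the aryl group at this position even when the group that leaves and the group that enters match in heavy-atom count, hydrogen-bond donors, hydrogen-bond acceptors and net charge, so these counts alone do not settle the value here. No measured evidence is available to explain the step.

From the compounds shown here alone, this one pair changes both the substituent and where it stands on the ring, so it remains open whether the step belongs to the chlorine or to its place, a question that 2-methylphenyl or 3-chlorophenyl on the same nitrogen would address. Going by these compounds, it also remains open whether the number would move further with an aryl ring bearing an amine or a carboxylic acid, or with a longer chain in place of the ring.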